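The source may hold more compounds than are shown below. What is called first, only, known or untested is meant among the compounds shown, and "the series" means these compounds.

Of the compounds shown here, two of a shared core have been measured in a functional assay on SR cells (Homo sapiens) for inhibition, read by sulforhodamine B assay, with a stated time of 48 h; a lower number here means a stronger inhibitor of growth, a higher number a weaker inhibitor of growth. Compound 1 `O=C(Nc1cccc(-n2cc(-c3ccncc3)c(-c3ccc(Cl)c(O)c3)n2)c1)Nc1cccc(C(F)(F)F)c1` gives 1820 nM there. Compound 2 `COc1cc(-c2nn(-c3cccc(NC(=O)Nc4cc(C(F)(F)F)cc(C(F)(F)F)c4)c3)cc2-c2ccncc2)ccc1Cl` gives 1080 nM in this assay; it has the lower of the two numbers, though the gap to compound 1 lies within the scatter. Compound 3 `O=C(Nc1cccc(-n2cc(-c3ccncc3)c(-c3ccc(Cl)c(O)c3)n2)c1)Nc1cc(C(F)(F)F)cc(C(F)(F)F)c1` arises from compound 2 by hydrogen in place of methyl on an oxygen on an aromatic ring. Among the compounds with values here, no measured pair shows this change alone, so no step larger than the scatter is expected in either direction. Compound 3 is therefore estimated at 1000 nM in this assay, within 400 nM to 2500 nM, a step of a 1.1-fold lower number from compound 2 to compound 3 (0.03 log units; within the scatter) that is expected to stay inside the scatter.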

Compound 3, concentration for 50% growth inhibition: 922 nM
Compound 3: middle estimate off by 1.1-fold (0.04 log units), on the high side; measured number inside the range.
By their numbers in this assay, from the lowest: compounds 3, 2 and 1 (each within the scatter of the next).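

In this assay, within the data shown here, hydroxy and methoxy on the oxygen-bearing aromatic position are not separated, with a 1.2-fold lower number from compound 2 to compound 3 (0.07 log units; within the scatter), so the first direct pair at this position shows that this exchange alone gives a step inside the scatter. A second pair, with trifluoromethyl in place of hydrogen on an aromatic carbon, gives a 2.0-fold lower number from compound 1 to compound 3 (0.30 log units; within the scatter), also within the scatter. No measurement offered here accounts for either step. The compounds shown leave open whether an amine or a longer chain such as ethoxy at this oxygen-bearing position would give a step beyond the scatter. They also leave open whether either step would hold on a different core.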